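The compounds below may be only part of what the source reports. "The series", "measured", "known", "first", "only" and "open" are said of these compounds alone.

Compound 1, `CCOC(=O)c1cnc(-n2nc(C)cc2C)nc1NN1C(=O)C=C(C)C1=O`, in a functional assay on Jurkat cells for inhibition of nuclear factor NF-kappa-B complex (Homo sapiens) (a higher number here means a weaker inhibitor, a lower number a stronger inhibitor), gives 10000 nM.
Compound 2, `CCOC(=O)c1cnc(C(=O)c2ccco2)nc1NN1C(=O)C=C(C)C1=O`, in this assay gives 700 nM.
Compound 3, `CC1=CC(=O)N(Nc2nc(-c3cccs3)ncc2-c2cc(C)no2)C1=O`, in this assay gives 300 nM.

Among these three, compound 3 has the lowest number and so is the strongest inhibitor of the set. Its nearest neighbour is compound 2, whose number is higher by an amount that falls beyond the usual scatter of repeated measurements; compound 1 lies much further away, with a number far higher than that of compound 3.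

Compound 4, `CC1=CC(=O)N(Nc2nc(-c3cccs3)ncc2-c2nnc(C)o2)C1=O`, is compound 3 with one change: 5-methyl-1,3,4-oxadiazol-2-yl in place of 3-methyl-1,2-oxazol-5-yl on an aromatic carbon. For the measured compounds named here, the only measured step in which two compounds differ at a single place is a 14-fold lower number from compound 1 to compound 2 (1.15 log units; beyond the scatter), and that step concerns a different position of the shared core and different groups, so it says nothing direct about the change from compound 3 to compound 4. The swap in compound 4 keeps the same count of heavy atoms and the same ring size, and nothing measured here speaks for a large shift in either direction. The estimate for compound 4 is therefore a step of a 1.3-fold higher number from compound 3 to compound 4 (0.12 log units; within the scatter), kept close to the scatter. Compound 4 is expected to give 400 nM, within a range from 150 nM to 1200 nM.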

Compound 4, half-maximal inhibitory concentration: 300 nM
Beside the measured number, compound 4's estimate is 1.3-fold (0.12 log units) above it; the range from low to high includes it.
By their numbers in this assay, from the lowest: compounds 3 and 4 (each within the scatter of the next); then compound 2; then compound 1.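

Replacing 3-methyl-1,2-oxazol-5-yl with 5-methyl-1,3,4-oxadiazol-2-yl on the aromatic carbon para to the thiophen-2-yl group gives no change at the digits printed from compound 3 to compound 4 (within the scatter) in this assay. For the compounds shown here, this is the first step read at this position, as the earlier step concerned a different place on the shared core, and it shows that the number holds when a five-membered aromatic ring with 2 hetero atoms gives way to one with 3 hetero atoms, one of the two ring carbons being exchanged for a nitrogen while the methyl group stays on the ring. No measurement is available that explains why the two compounds sit so close together.

As far as these compounds go, both groups at this position are methyl-bearing five-membered aromatic rings, so it remains open whether the number would hold with a very different group there, such as a carboxylic acid, an amine or a longer alkyl chain. From the compounds shown here alone, it is also open what the methyl group itself contributes, and whether this ring swap would give the same result with something other than thiophen-2-yl on the far side of the shared core.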